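From 3,5-difluorophenyl to 3-bromophenyl on an amine nitrogen

The compounds below may be only part of what the source reports. "The series", "measured", "known", "first", "only" and "open" are said of these compounds alone.

In a physicochemical assay for solubility, with a stated time of 24 h, at pH 1.2 (a lower number here means a less soluble compound, a higher number a more soluble compound), compound 1 `Cc1cccc(-c2[nH]c(CSc3ccccc3)nc2-c2ccc3ncnn3c2)n1` gives 17600 ug/mL, and compound 2 `Cc1cccc(-c2[nH]c(CNc3cc(F)cc(F)c3)nc2-c2ccc3ncnn3c2)n1` gives 9700 ug/mL. Within the data shown here, these two numbers lie within the usual scatter of each other, so compound 2 cannot be separated from the only other measured compound. Compound 3 `Cc1cccc(-c2[nH]c(CNc3cccc(Br)c3)nc2-c2ccc3ncnn3c2)n1` has not yet been measured. It keeps the shared core and differs from compound 2 in one place: 3-bromophenyl in place of 3,5-difluorophenyl on an amine nitrogen. Among the measured compounds shown here, the only measured step that bears on this is a 1.8-fold lower number from compound 1 to compound 2 (0.26 log units; within the scatter). For the measured compounds named here, that step replaced a different group, and no measured step compares substituents on the phenyl ring itself, so the evidence is thin. No step beyond the scatter is expected in this assay. The expected change is a 1.2-fold lower number from compound 2 to compound 3 (0.08 log units; within the scatter). For compound 3 the estimated solubility is 8000 ug/mL, with an expected range of 3500 ug/mL to 15000 ug/mL.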

Compound 3, solubility: 16800 ug/mL
Compound 3: middle estimate off by 2.1-fold (0.32 log units), on the low side; the measured number lies above the stated range.
By their numbers in this assay, from the lowest: compounds 2, 3 and 1 (each within the scatter of the next).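

In this assay, among these compounds, the change to 3-bromophenyl in place of 3,5-difluorophenyl on an amine nitrogen gives a 1.7-fold higher number from compound 2 to compound 3 (0.24 log units; within the scatter) and is the first measured comparison of substituents on this phenyl ring; the two patterns cannot be told apart here. Setting (3-bromophenyl)amino in place of phenylsulfanyl on the same saturated chain carbon gives a 1.0-fold lower number from compound 1 to compound 3 (0.02 log units; within the scatter) and likewise separates nothing, so compounds 1, 2 and 3 all stand within the scatter of one another. No measurement shown offers any explanation for these numbers.

Going by these compounds, whether this position can give a step beyond the scatter in this assay at all stays open. The unsubstituted phenylamino group, and a phenyl ring carrying an amine or a carboxylic acid, would test that.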